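A Ring Swap on a Weakly Cytotoxic Compound

A few compounds are considered here, and "the series" means these few. Any claim that something is new, unique, unknown or untested is made for them only; others in the source may bear on it.

In a functional assay on HCT-116 cells (Homo sapiens) for cytotoxicity, read by MTT assay, with a stated time of 72 h (on this read-out higher numbers stand for weaker inhibition and lower numbers for stronger inhibition), compound 1 `O=S(=O)(c1ccccc1)c1nc2ccccc2nc1N1CCCC1` gives 24200 nM as its value. Compound 3 `O=S(=O)(c1ccc(Br)cc1)c1nc2ccccc2nc1N1CCCC1` gives 37700 nM here, within the scatter of compound 1. Compound 2 `Cc1ccc(S(=O)(=O)c2nc3ccccc3nc2N2CCCC2)cc1` shows only a limit of the assay, > 50000 nM and no number. Compound 4 `O=S(=O)(c1ccc(Br)cc1)c1nc2ccccc2nc1N1CCCC(O)C1` has 3-hydroxypiperidin-1-yl in place of the pyrrolidin-1-yl of compound 3 on an aromatic carbon, a change summed up as 3-hydroxypiperidin-1-yl in place of pyrrolidin-1-yl on an aromatic carbon in full. Among the measured compounds shown here, two measured steps bear on it only loosely: an at least 2.0-fold higher number from compound 1 to compound 2 (0.31 log units; beyond the scatter) and a 1.6-fold higher number from compound 1 to compound 3 (0.19 log units; within the scatter) both changed a different place. No shift beyond the scatter is therefore expected in this assay for this swap. The estimated change is a 1.3-fold lower number from compound 3 to compound 4 (0.10 log units; within the scatter) at its middle. Compound 4 is expected at 30000 nM with an estimated range from 12000 nM to 50000 nM overall.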

Compound 4, half-maximal inhibitory concentration: 2110 nM
Compound 4: middle estimate off by 14-fold (1.15 log units), on the high side; measured number outside the range, below it.
By their numbers in this assay, from the lowest: compound 4; then compounds 1 and 3 (each within the scatter of the next). At a limit, above all of these: compound 2.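

In this assay, 3-hydroxypiperidin-1-yl in place of pyrrolidin-1-yl on the aromatic carbon next to the ring nitrogen gives an 18-fold lower number from compound 3 to compound 4 (1.25 log units; beyond the scatter). Among the compounds shown here, the earlier steps all changed a different place, so this is the first sign that the group at this position strongly affects the read-out. Nothing measured here explains the size of this step.

The swap enlarges the ring and adds a hydroxyl group in one move, so the two changes cannot be told apart. Plain piperidin-1-yl and 3-aminopiperidin-1-yl at this position would help separate them.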